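Methoxy in Place of Isopropyl: Expected Tolerance of Compound 4

A few compounds are considered here, and "the series" means these few. Any claim that something is new, unique, unknown or untested is made for them only; others in the source may bear on it.

Compound 1 `CNC(=O)c1cc(Oc2ccc(-c3noc(CC(C)C)n3)cc2)ccn1`: 23400 nM
Compound 2 `CNC(=O)c1cc(Oc2ccc(-c3noc(COC)n3)cc2)ccn1`: 63400 nM
Compound 3 `CNC(=O)c1cc(Oc2cccc(-c3noc(CC(C)C)n3)c2)ccn1`: 19100 nM

These three compounds were measured in an ADME assay on H1-HeLa cells (Homo sapiens) for cytotoxicity, read by MTT assay, with a stated time of 3 days; a higher number here means that more compound is tolerated, a lower number that less compound is tolerated. Compound 1 and compound 2 share one core and differ by methoxy in place of isopropyl on a saturated chain carbon bound to an aromatic carbon; this change gave a 2.7-fold higher number from compound 1 to compound 2 (0.43 log units; beyond the scatter). Compound 3 carries a different core, and the difference between the two cores is not broken down here; in this assay compound 3 gives a value within the scatter of that of compound 1, while compound 2 gives a number beyond the scatter above both.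

Compound 4 `CNC(=O)c1cc(Oc2cccc(-c3noc(COC)n3)c2)ccn1` has not yet been measured. It stands to compound 3 as compound 2 stands to compound 1: it differs by methoxy in place of isopropyl on a saturated chain carbon bound to an aromatic carbon, the same change at the same place. Going by the values given here, on that basis compound 4 is expected to show a 2.6-fold higher number from compound 3 to compound 4 (0.42 log units; beyond the scatter), of about the size seen as a 2.7-fold higher number from compound 1 to compound 2 (0.43 log units; beyond the scatter), though the single earlier example gives no measure of how far the step depends on the core. For compound 4 the estimated value in this assay is 50000 nM, expected to lie between 25000 nM and 100000 nM.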

Compound 4, half-maximal cytotoxic concentration: > 100000 nM
Compound 4 gave a limit, no number (the forecaster's own chance of this, stated with the estimate: 5%); at least 2.0-fold (0.30 log units) between middle value and limit.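

In this assay, methoxy in place of isopropyl on a saturated chain carbon bound to an aromatic carbon moved the number in the same direction on both cores, and on the second core it gave an at least 5.2-fold higher number from compound 3 to compound 4 (0.71 log units; beyond the scatter). Compound 4 gives > 100000 nM, which is a limit of the assay and not a number, so this step has a bound but no measured size. The direction of the change therefore carried over from one core to the other, but this does not show that its size carried over with it: the same change on two cores in this assay, a 2.7-fold higher number (0.43 log units; beyond the scatter) from compound 1 to compound 2 and an at least 5.2-fold higher number (0.71 log units; beyond the scatter) from compound 3 to compound 4; the limit leaves it open whether they differ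

The compounds shown leave open whether the same direction would hold on a third core, since only two cores carry this change here. They also leave open how this assay would respond if an amine, a carboxylic acid or a longer chain stood at this place instead of isopropyl or methoxy.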